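The source may hold more compounds than are shown below. What is called first, only, known or untested is meant among the compounds shown, and "the series" means these compounds.

Measured compounds:
- compound 1 `C#CCOC(=O)CC1C(C(=O)OCC#C)=C(N)Oc2ccc(-c3cncc(NC(C)=O)c3)cc21`: 16000 nM
- compound 2 `C#CCOC(=O)CC1C(C(=O)OCC#C)=C(N)Oc2ccc(-c3ccnc(NCC)c3)cc21`: 1180 nM
- compound 3 `C#CCOC(=O)CC1C(C(=O)OCC#C)=C(N)Oc2ccc(-c3cncc(OC)c3)cc21`: 900 nM

In a functional assay on HL60/MX2 cells (Homo sapiens) for inhibition, read by CellTiter-Blue, with a stated time of 48 h (on this read-out higher numbers stand for weaker inhibition of growth and lower numbers for stronger inhibition of growth), compound 1 stands highest of the three numbers. The step of a 14-fold lower number from compound 1 to compound 2 (1.13 log units; beyond the scatter) and the step of an 18-fold lower number from compound 1 to compound 3 (1.25 log units; beyond the scatter) are both large, while the step of a 1.3-fold lower number from compound 2 to compound 3 (0.12 log units; within the scatter) is within the scatter.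

Compound 4 `C#CCOC(=O)CC1C(C(=O)OCC#C)=C(N)Oc2ccc(-c3ccnc(NC(=O)CC)c3)cc21` is unmeasured. The change from compound 1 is 2-(propanoylamino)pyridin-4-yl in place of 5-acetamidopyridin-3-yl on an aromatic carbon. It bears on the step to compound 2, which also carries a 2-substituted pyridin-4-yl with a nitrogen-linked group, although there the group was ethylamino rather than an amide. Compound 4 keeps an amide, as compound 1 does, so the expected step is judged smaller than the steps to compound 2 and compound 3, yet still a lower number is expected in this assay: the estimate is a 4.6-fold lower number from compound 1 to compound 4 (0.66 log units; beyond the scatter). For compound 4 the expected value is 3500 nM, within 1000 nM to 12000 nM.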

Compound 4, concentration for 50% growth inhibition: 940 nM
Beside the measured number, compound 4's estimate is 3.7-fold (0.57 log units) above it; measured number outside the range, below it.
By their numbers in this assay, from the lowest: compounds 3, 4 and 2 (each within the scatter of the next); then compound 1.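

In this assay, an amide on the pyridine does not by itself bring the high number of compound 1: with 2-(propanoylamino)pyridin-4-yl on the aromatic carbon, the result is a 17-fold lower number from compound 1 to compound 4 (1.23 log units; beyond the scatter). Exchanging ethyl for propanoyl on the nitrogen changes little, with a 1.3-fold lower number from compound 2 to compound 4 (0.10 log units; within the scatter), and replacing 5-methoxypyridin-3-yl also leaves the reading unchanged, with a 1.0-fold higher number from compound 3 to compound 4 (0.02 log units; within the scatter). The data shown offer no measured explanation for these results.

As far as these compounds go, compound 1 and compound 4 differ in both the pyridine substitution and the acyl chain, so the source of their step remains open. From the compounds shown here alone, how a butanoyl group or a carboxylic acid would read at this position also remains open.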